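Combining chloro and trifluoromethyl on the pendant aryl ether

A few compounds are considered here, and "the series" means these few. Any claim that something is new, unique, unknown or untested is made for them only; others in the source may bear on it.

The series shares a core carrying a pendant aryl ether; compound 1 `Cc1cn(C2CCN(Cc3cccc(Oc4cccc(Cl)c4)c3)CC2)c(=O)[nH]c1=O` bears a 3-chlorophenyl there, compound 2 `Cc1cn(C2CCN(Cc3cccc(Oc4cccc(C(F)(F)F)c4)c3)CC2)c(=O)[nH]c1=O` a 3-(trifluoromethyl)phenyl, and compound 3 `Cc1cn(C2CCN(Cc3cccc(Oc4cccnc4)c3)CC2)c(=O)[nH]c1=O` a pyridin-3-yl. In an ADME assay on MRC5 cells (Homo sapiens) for cytotoxicity, read by fluorescence and resazurin assay, with a stated time of 3 days (on this read-out lower numbers stand for stronger inhibition and higher numbers for weaker inhibition), compound 1 gives 21000 nM and compound 2 gives 12400 nM; the step of a 1.7-fold lower number from compound 1 to compound 2 (0.23 log units; within the scatter). For compound 3 this assay reports only a limit, > 64000 nM, so compound 3 stands at the weak end of the numbers shown (the limit of > 64000 nM in this assay, at which 1 of the 3 values shown sits). The steps of an at least 3.0-fold higher number from compound 1 to compound 3 (0.48 log units; beyond the scatter) and an at least 5.1-fold higher number from compound 2 to compound 3 (0.71 log units; beyond the scatter) both run toward that limit.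

Compound 4 `Cc1cn(C2CCN(Cc3cccc(Oc4ccc(Cl)c(C(F)(F)F)c4)c3)CC2)c(=O)[nH]c1=O` has not been measured. It differs from compound 3 by 4-chloro-3-(trifluoromethyl)phenyl in place of pyridin-3-yl on an oxygen on an aromatic ring, so it carries both substituents seen on compound 1 and compound 2. Since the moves toward pyridin-3-yl raised the number in both measured steps, the reverse move is expected to lower it, by an estimated at least 7.1-fold lower number from compound 3 to compound 4 (0.85 log units; beyond the scatter). For compound 4 in this assay a value of 9000 nM is expected, estimated between 4000 nM and 25000 nM.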

Compound 4, half-maximal inhibitory concentration: 5280 nM
For compound 4 the middle estimate is 1.7-fold (0.23 log units) above the measured one; the measured number falls inside the stated range.
By their numbers in this assay, from the lowest: compound 4; then compounds 2 and 1 (each within the scatter of the next). At a limit, above all of these: compound 3.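

In this assay, chloro in place of hydrogen on the aromatic ring gives a 2.3-fold lower number from compound 2 to compound 4 (0.37 log units; beyond the scatter), and the 4-chloro-3-(trifluoromethyl)phenyl gives a 4.0-fold lower number from compound 1 to compound 4 (0.60 log units; beyond the scatter), so the two substituents together produce steps beyond the scatter, unlike the exchange of one for the other in a 1.7-fold lower number from compound 1 to compound 2 (0.23 log units; within the scatter). The widest step at this position, on an oxygen on an aromatic ring, is an at least 12-fold lower number from compound 3 to compound 4 (1.08 log units; beyond the scatter), which replaces the pyridin-3-yl with a larger carbon-only ring. Its true size is unknown, as compound 3 has only a limit and not a number: the limit of > 64000 nM in this assay, at which 1 of the 4 values shown sits.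

The compounds shown do not tell what a 4-chlorophenyl alone would give on that oxygen. They also leave open whether a methyl or an amine in place of the chloro would lower the number in the same way.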